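A few compounds are considered here, and "the series" means these few. Any claim that something is new, unique, unknown or untested is made for them only; others in the source may bear on it.

Compound 1 `CCNC(=O)N1CCN(C(=S)SCc2cn(Cc3ccc(F)cc3)nn2)CC1`: 27800 nM
Compound 2 `CCN(C)C(=O)N1CCN(C(=S)SCc2cn(Cc3ccc(F)cc3)nn2)CC1`: 14300 nM

Going by the values given here, compound 2 holds the lowest of the two numbers so far in a functional assay on EC9706 cells (Homo sapiens) for cytotoxicity, read by MTT assay, with a stated time of 72 h (a higher number here means a weaker inhibitor, a lower number a stronger inhibitor), but its only neighbour is compound 1, and a 1.9-fold lower number from compound 1 to compound 2 (0.29 log units; within the scatter), so the two compounds are not separated on this read-out.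

Compound 3 `O=C(NC1CCCCC1)N1CCN(C(=S)SCc2cn(Cc3ccc(F)cc3)nn2)CC1` remains to be measured. Its change against compound 2 is cyclohexylamino in place of ethyl(methyl)amino on a carbonyl carbon. Among the compounds with values here, the single measured step, the methyl in place of hydrogen on the amide-type nitrogen from compound 1 to compound 2, is the only one that touches this carbonyl substituent, and it stayed within the scatter. Within the data shown here, no measured step covers a ring entering at this place, nor the return of a hydrogen-bond donor, so the data give no basis for a move beyond the scatter in either direction. Compound 3 is therefore expected to show a 1.0-fold higher number from compound 2 to compound 3 (0.02 log units; within the scatter). The estimate for compound 3 is 15000 nM, within the range 5000 nM to 45000 nM.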

Compound 3, half-maximal inhibitory concentration: > 128000 nM
Compound 3: no number, only a limit; the forecaster's own chance of this, stated with the estimate: 5%; at least 8.5-fold (0.93 log units) between middle value and limit.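

Compound 3 gives only a limit of the assay, not a number, in this assay: the limit of > 128000 nM in this assay, at which 1 of the 3 values shown sits.

Even so, the carbonyl substituent is shown to matter here, since the change to cyclohexylamino gives an at least 8.9-fold higher number from compound 2 to compound 3 (0.95 log units; beyond the scatter), whereas the earlier change at this substituent stayed within the scatter, with a 1.9-fold lower number from compound 1 to compound 2 (0.29 log units; within the scatter). Compound 1 and compound 3 both keep the amide hydrogen, yet cyclohexyl in place of ethyl on the amide-type nitrogen still gives an at least 4.6-fold higher number from compound 1 to compound 3 (0.66 log units; beyond the scatter), so the presence of that hydrogen alone does not separate the active compounds from the limit.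

The compounds shown do not tell whether the ring itself or simply the larger group carries this step. Cyclopropylamino, an open-chain hexylamino or a morpholine on the same carbonyl carbon would bear on that question.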